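This account rests on a few compounds, and the source may have more. Where it says the series, first, only, none or still open, it means among the compounds named here.

Within the data shown here, compound 1 `CC(=O)NCC(=O)N(C)c1ccc(Cl)cc1C(=O)c1ccccc1Cl` is the only compound in this set for which a functional assay on the whole organism with Mus musculus as the target, in the rotarod test (on this read-out higher numbers stand for an effect only at larger amounts of compound and lower numbers for an effect already at smaller amounts), returns a number: compound 1 gives 58 mg/kg. Compound 3 `CC(=O)NCC(=O)Nc1ccc(Cl)cc1C(=O)c1ccccc1Cl` reaches only the limit of this assay, > 100 mg/kg. Compound 2 `NC(C(=O)NCC(=O)Nc1ccc(Cl)cc1C(=O)c1ccccc1)c1ccccc1` likewise reaches only the limit, > 100 mg/kg. Among the measured compounds shown here, two of the three results thus stop at the limit of > 100 mg/kg in this assay, at which 2 of the 3 values shown sit, and the one measured step, an at least 1.7-fold higher number from compound 1 to compound 3 (0.23 log units; that floor lies within the scatter), is itself only a floor. That step concerns hydrogen in place of methyl on an amide-type nitrogen, a different place from the change now under study. Compound 4 `CN(C)CC(=O)NCC(=O)N(C)c1ccc(Cl)cc1C(=O)c1ccccc1Cl` differs from compound 1 as follows: dimethylamino in place of hydrogen on a saturated chain carbon bound to a carbonyl carbon. For the measured compounds named here, no measured step involves a saturated chain carbon bound to a carbonyl carbon, and the values shown give no direction for such a change. The expectation for compound 4 is therefore a step of no change at the digits printed from compound 1 to compound 4 (within the scatter), nothing beyond the scatter. In this assay compound 4 is expected to give 58 mg/kg, with a range from 25 mg/kg to 140 mg/kg.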

Compound 4, dose for half-maximal effect: 26 mg/kg
Compound 4: the middle estimate sits 2.2-fold (0.35 log units) above what was measured, and the stated range covers the measured number.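

Dimethylamino in place of hydrogen on a saturated chain carbon bound to a carbonyl carbon gives a 2.2-fold lower number from compound 1 to compound 4 (0.35 log units; beyond the scatter) in this assay. This gives the position its first measured direction, and although the step is modest, it lies beyond the scatter. It is also the only step in the set with a number at both ends, whereas the earlier step on the amide-type nitrogen is only a floor, and much of the series remains unquantified: the limit of > 100 mg/kg in this assay, at which 2 of the 4 values shown sit.

One step cannot say whether the lower number is particular to dimethylamino or would also follow from a primary amine, a piperidine ring, a carboxylic acid or a longer chain on the same carbon. From the compounds shown here alone, it also remains open whether dimethylamino would give a similar step on the core of compound 3, which keeps the amide hydrogen.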